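Nitro to cyano on a chlorinated aryl glycoside

A few compounds are considered here, and "the series" means these few. Any claim that something is new, unique, unknown or untested is made for them only; others in the source may bear on it.

compound 1 `O=[N+]([O-])c1ccc(-c2ccc(O[C@H]3O[C@H](CO)[C@@H](O)[C@H](O)[C@@H]3O)c(Cl)c2)cc1` — a physicochemical assay for lipophilicity, read by LC-MS, measured as octanol-water partition, with a stated time of 2 h, at pH 7.4, tested at 1 uM; on this read-out lower numbers stand for lower lipophilicity and higher numbers for higher lipophilicity: 2.3
compound 2 `OC[C@H]1O[C@H](Oc2ccc(-c3ccc(Cl)c(C(F)(F)F)c3)cc2Cl)[C@@H](O)[C@@H](O)[C@@H]1O` — "not determined" (no result reported)

Within the data shown here, compound 1 is the only member of the series with a number in this assay; compound 2 has none, so no step between measured compounds is available. Compound 3 `N#Cc1ccc(-c2ccc(O[C@H]3O[C@H](CO)[C@@H](O)[C@H](O)[C@@H]3O)c(Cl)c2)cc1` differs from compound 1 by cyano in place of nitro on an aromatic carbon. Among the measured compounds shown here, with no measured step to lean on, the expectation rests on compound 1 alone. From compound 1 to compound 3 the step is expected to be small and downward, a number 0.30 log units lower from compound 1 to compound 3 (within the scatter), close to the usual scatter. Compound 3 is therefore estimated at 2, within 1.6 to 2.4.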

Compound 3, distribution coefficient: 2.1
For compound 3 the middle estimate is 0.10 log units below the measured one, and the stated range covers the measured number.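

Exchanging nitro for cyano on an aromatic carbon para to a large group gives a number 0.20 log units lower from compound 1 to compound 3 (within the scatter) in this assay. Among these compounds, this is the first measured step, and at this position the read-out does not separate 4-nitrophenyl from 4-cyanophenyl on the shared core. Nothing available accounts for this result.

As far as these compounds go, whether an amine, a carboxylic acid or a longer chain at this position would stay as close to compound 1 remains open. Also open, from the compounds shown here alone, is whether the same exchange would give a similar step on a different core.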